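The compounds below may be only part of what the source reports. "The series", "measured", "known", "first", "only" and "open" are said of these compounds alone.

Of the compounds shown here, three of a shared core have been measured in an assay on HEK293 cells for binding affinity to Urotensin-2 receptor (Homo sapiens), read by radioligand binding; on this read-out higher numbers stand for weaker inhibition and lower numbers for stronger inhibition. Compound 1 `CC(C)C[C@H](NC(=O)c1cc2ccccc2o1)C(=O)N[C@H]1CCN(Cc2ccc(OCCCN(C)C)cc2)C1` gives 158 nM. Compound 2 `CC(C)C[C@H](NC(=O)c1ccc(Br)cc1)C(=O)N[C@H]1CCN(Cc2ccc(OCCCN(C)C)cc2)C1` gives 200 nM. Compound 3 `CC(C)C[C@H](NC(=O)c1ccco1)C(=O)N[C@H]1CCN(Cc2ccc(OCCCN(C)C)cc2)C1` gives 631 nM, the highest of the three numbers; its nearest neighbour is compound 2, and the gap to compound 1 is wider still, both beyond the scatter.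

Compound 4 `CC(C)C[C@H](NC(=O)c1ccccc1)C(=O)N[C@H]1CCN(Cc2ccc(OCCCN(C)C)cc2)C1` differs from compound 3 by phenyl in place of furan-2-yl on a carbonyl carbon. Two of the measured steps bear on it, since each replaces the group on that carbonyl carbon. There was a 3.2-fold higher number from compound 2 to compound 3 (0.50 log units; beyond the scatter) and a 4.0-fold higher number from compound 1 to compound 3 (0.60 log units; beyond the scatter), so the furan-2-yl group gave the weakest binding of the three groups tried. Reversing that direction with a six-membered carbon-only ring is expected to bring the number back down by a modest amount, though the absence of the bromine atom of compound 2 leaves the size uncertain; the expected step is a 2.1-fold lower number from compound 3 to compound 4 (0.32 log units; beyond the scatter). For compound 4 the estimate in this assay is 300 nM, with a range from 120 nM to 800 nM.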

Compound 4, inhibition constant: 501 nM
Compound 4: the middle estimate sits 1.7-fold (0.22 log units) below what was measured; low and high end bracket the measured number.
By their numbers in this assay, from the lowest: compounds 1 and 2 (each within the scatter of the next); then compounds 4 and 3 (each within the scatter of the next).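

In this assay, the change of furan-2-yl to phenyl on the carbonyl carbon leaves the two groups indistinguishable (a 1.3-fold lower number from compound 3 to compound 4 (0.10 log units; within the scatter)), so swapping this five-membered aromatic ring with one oxygen for a six-membered ring of carbon only shows no measurable effect. The two other steps show that the plain phenyl group does not carry the binding of the earlier groups: hydrogen in place of bromo on an aromatic carbon separates it from the 4-bromophenyl group (a 2.5-fold higher number from compound 2 to compound 4 (0.40 log units; beyond the scatter)), and phenyl in place of 1-benzofuran-2-yl separates it from that group as well (a 3.2-fold higher number from compound 1 to compound 4 (0.50 log units; beyond the scatter)). Nothing at hand explains why the bromo group and the benzofuran ring differ from the plain ring in this way.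

As far as these compounds go, whether a chloro or methoxy group in place of bromo, or a naphthyl group on the carbonyl carbon, would give a number like that of compound 2 stays open. From the compounds shown here alone, the effect of another amine or a longer chain elsewhere on the shared core also remains unknown.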